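The compounds below may be only part of what the source reports. "The series", "measured", "known", "first", "only" and "open" are said of these compounds alone.

Of the compounds shown here, two have been measured in an assay on membranes from Sf9 cells for displacement of a labelled ligand from histamine H2 receptor (Homo sapiens), read by scintillation counting, with a stated time of 60 min; on this read-out higher numbers stand for weaker inhibition and lower numbers for stronger inhibition. Compound 1, `CCCNC(=O)/N=C(\N)Nc1cccc(-c2csc(N)n2)c1`, gives 5250 nM in this assay. Compound 2, `Cc1nc(N)sc1CCCN/C(N)=N/C(=O)NC(C)c1ccccc1F`, gives 28.8 nM in this assay, the lowest of the two numbers and so the stronger inhibitor, with a gap from compound 1 that lies well beyond the usual scatter. Compound 3, `Cc1nc(N)sc1CCCN/C(N)=N/C(=O)NC(C)c1cccs1`, has not been measured. It differs from compound 2 in one place: thiophen-2-yl in place of 2-fluorophenyl on a saturated chain carbon bound to an amide-type nitrogen and a saturated chain carbon. Among the compounds with values here, no measured pair shows what such an exchange does here, so the expectation rests on compound 2 alone. A five-membered aromatic ring replacing a six-membered one on the same saturated chain carbon is a small change, and the step from compound 2 to compound 3 in this assay is expected to be modest, toward weaker inhibition or none beyond the scatter, a 1.6-fold higher number from compound 2 to compound 3 (0.19 log units; within the scatter). Compound 3 is therefore estimated at 45 nM, within a range from 12 nM to 160 nM.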

Compound 3, inhibition constant: 63.1 nM
Compound 3: middle estimate off by 1.4-fold (0.15 log units), on the low side, within the range that was stated.
By their numbers in this assay, from the lowest: compound 2; then compound 3; then compound 1.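

In this assay, within the data shown here, this pair gives the first direct reading at this position: thiophen-2-yl in place of 2-fluorophenyl on the saturated chain carbon gives a 2.2-fold higher number from compound 2 to compound 3 (0.34 log units; beyond the scatter). The step is modest but beyond the scatter, so the two rings are not fully interchangeable here, although the smaller ring with one hetero atom costs only this limited weakening. No measurement on these compounds accounts for the step.

This single exchange removes the fluorine and changes the ring at once, so the compounds shown cannot separate the two changes. Plain phenyl would help to separate them, while pyridin-2-yl or cyclohexyl on the same carbon would show how far this position accepts other rings.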